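Chalcone aryl swap on the methoxyphenyl core series

This account rests on a few compounds, and the source may have more. Where it says the series, first, only, none or still open, it means among the compounds named here.

Measured so far:
- compound 1 `COc1cc(/C=C/C(=O)c2cccc(-n3cc(-c4ccc(Cl)cc4)[nH]c3=O)c2)ccc1O`: 2840 nM
- compound 2 `COc1ccc(-c2cn(-c3cccc(C(=O)/C=C/c4cc(OC)c(OC)c(OC)c4)c3)c(=O)[nH]2)cc1`: 5910 nM

In a functional assay on HOP-62 cells (Homo sapiens) for inhibition (a lower number here means a stronger inhibitor of growth, a higher number a weaker inhibitor of growth), compound 2 gives 5910 nM, the higher of the two numbers recorded; its nearest neighbour is compound 1 at 2840 nM, and that gap is beyond the scatter, so compound 2 stands as the weaker inhibitor of growth of the pair. For the measured compounds named here, no single-point step between the two measured compounds exists, as they differ in more than one place, so the data so far give no isolated read on either part of the molecule.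

Compound 3 `COc1ccc(-c2cn(-c3cccc(C(=O)/C=C/c4ccc(O)c(OC)c4)c3)c(=O)[nH]2)cc1` has not yet been tested. Its difference from compound 2 is 4-hydroxy-3-methoxyphenyl in place of 3,4,5-trimethoxyphenyl on a double-bonded chain carbon bound to a double-bonded chain carbon. Compound 1 carries the same 4-hydroxy-3-methoxyphenyl on its chain but a different group on the core, so it can only hint at the direction. With that hint, compound 3 is expected to give a somewhat lower number than compound 2 in this assay, a step of a 1.7-fold lower number from compound 2 to compound 3 (0.23 log units; within the scatter), though a result within the scatter would not surprise. The estimate for compound 3 is 3500 nM, within 1500 nM to 8000 nM.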

Compound 3, concentration for 50% growth inhibition: 5150 nM
Compound 3: the middle estimate sits 1.5-fold (0.17 log units) below what was measured, and the stated range covers the measured number.
By their numbers in this assay, from the lowest: compounds 1, 3 and 2 (each within the scatter of the next, the first and the last beyond it).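

In this assay the swap on the double-bonded chain carbon bound to a double-bonded chain carbon gives a 1.1-fold lower number from compound 2 to compound 3 (0.06 log units; within the scatter) and so does not separate 4-hydroxy-3-methoxyphenyl from 3,4,5-trimethoxyphenyl, even though the entering group brings a hydrogen-bond donor that the leaving group lacks. The series also gains its first single-place read on the other side of the molecule, where methoxy in place of chloro on an aromatic carbon gives a 1.8-fold higher number from compound 1 to compound 3 (0.26 log units; within the scatter) and likewise stays unresolved in this assay. No supporting data accompany either step, so neither can be explained.

The compounds shown carry only methoxy and hydroxy groups on the chain aryl ring, so it remains open whether a dimethylamino group or a carboxylic acid on that ring would move the number beyond the scatter. At the aromatic carbon holding methoxy or chloro, a nitrile or a morpholine would test whether that place responds to anything other than these two groups.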